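A few compounds are considered here, and "the series" means these few. Any claim that something is new, unique, unknown or untested is made for them only; others in the source may bear on it.

Compound 1 `CCCc1ccc(/C=C/C(=O)Nc2ccc3nc(CCC)cc(N)c3c2)cc1` belongs to a small set of amides built on a shared core, and in a functional assay on HEK293 cells for activation of melanin-concentrating hormone receptor 1 (Homo sapiens), read by inositol phosphate accumulation (on this read-out higher numbers stand for an effect only at larger amounts of compound and lower numbers for an effect already at smaller amounts), compound 1 gives 3600 nM. Compound 2 `CC(C)(C)c1cc(N)c2cc(NC(=O)/C=C/c3ccc(C(F)(F)F)cc3)ccc2n1` gives 29 nM, and compound 3 `CCc1cc(N)c2cc(NC(=O)/C=C/c3ccc(C(F)(F)F)cc3)ccc2n1` gives 110 nM. Among these three numbers compound 1 stands highest, so it needs the largest amount of compound to act. Going by the values given here, the one single-point step known so far, a 3.8-fold higher number from compound 2 to compound 3 (0.58 log units; beyond the scatter), concerns the group on the core and not the outer ring.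

Compound 4 `CCCc1cc(N)c2cc(NC(=O)/C=C/c3ccc(Cl)cc3)ccc2n1` is reached from compound 1 by chloro in place of propyl on an aromatic carbon. Among the compounds with values here, no measured step touches this position, so the expectation can only lean on what compound 1 and compound 3 show together: they differ both at the core and on the outer ring, yet the core change alone, judged from the step of a 3.8-fold higher number from compound 2 to compound 3 (0.58 log units; beyond the scatter), covers only a small part of their gap. The remainder points to the group on the outer ring mattering a good deal, and chloro, like trifluoromethyl in compound 2 and compound 3, is a small group in that place.

A clear step downward is therefore expected, an 18-fold lower number from compound 1 to compound 4 (1.26 log units; beyond the scatter), and compound 4 is estimated at 200 nM, with a range from 60 nM to 700 nM.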

Compound 4, half-maximal effective concentration: 96 nM
The estimate for compound 4 lay 2.1-fold (0.32 log units) above the measured number; low and high end bracket the measured number.
By their numbers in this assay, from the lowest: compound 2; then compounds 4 and 3 (each within the scatter of the next); then compound 1.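

Replacing the 4-propylphenyl of compound 1 with the 4-chlorophenyl of compound 4 gives a 38-fold lower number from compound 1 to compound 4 (1.57 log units; beyond the scatter) in this assay. Going by these compounds alone, this is the first direct reading of the outer ring alone, with the propyl group on the shared core left in place, and it shows that a single exchange at this position can move the number by a large amount. Nothing measured here explains why propyl and chloro differ so much at this place.

The compounds shown leave open how the number responds to other groups at this position, such as methyl, methoxy or bromo, and whether an ethyl chain would already give part of this step. Going by these compounds, it also remains open whether the same exchange from propyl to chloro on the outer ring would give a step of similar size when the core carries ethyl or tert-butyl in place of propyl.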